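The compounds below may be only part of what the source reports. "The series", "measured", "known", "first", "only" and "open" are said of these compounds alone.

In a functional assay on HL-60 cells (Homo sapiens) for antiproliferative activity, read by CCK-8 assay, with a stated time of 72 h (on this read-out higher numbers stand for weaker inhibition and lower numbers for stronger inhibition), two compounds with a shared core have been measured, and they differ only in the group on a nitrogen on an aromatic ring. Compound 1 `Cc1cc(Nc2cc(N3CCN(C)CC3)nc(Nc3ccc([N+](=O)[O-])cc3)n2)n[nH]1`, which carries 4-nitrophenyl, gives 69.8 nM. Compound 2 `Cc1cc(Nc2cc(N3CCN(C)CC3)nc(Nc3cccc(Cl)c3)n2)n[nH]1`, which carries 3-chlorophenyl, gives 131 nM. Compound 2 can be set only against compound 1, and their two numbers lie within the scatter of each other, so the pair cannot be ranked.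

Compound 3 `COc1ccc(Nc2nc(Nc3cc(C)[nH]n3)cc(N3CCN(C)CC3)n2)cc1` has not yet been measured in this assay. It has 4-methoxyphenyl in place of 3-chlorophenyl on a nitrogen on an aromatic ring. Going by the values given here, only one measured step bears on this change. It concerns the same place, but neither of its compounds holds 4-methoxyphenyl, so it is thin evidence. That step, a 1.9-fold higher number from compound 1 to compound 2 (0.27 log units; within the scatter), stayed small, so no change beyond the scatter is expected. The expected size is a 1.3-fold lower number from compound 2 to compound 3 (0.12 log units; within the scatter). Compound 3 is estimated at 100 nM, with an expected range from 35 nM to 300 nM.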

Compound 3, half-maximal inhibitory concentration: 335 nM
Estimate against measurement, compound 3: 3.4-fold (0.53 log units) below, and the stated range ends below it.
By their numbers in this assay, from the lowest: compounds 1 and 2 (each within the scatter of the next); then compound 3.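

In this assay, the earlier pair had suggested that this place on a nitrogen on an aromatic ring tolerates exchange, since 4-nitrophenyl and 3-chlorophenyl could not be told apart. Compound 3 shows that the place is not indifferent to its group: a 2.6-fold higher number from compound 2 to compound 3 (0.41 log units; beyond the scatter) is a step beyond the scatter, so 4-methoxyphenyl is separated from 3-chlorophenyl as the earlier pair's groups were not. The second step, a 4.8-fold higher number from compound 1 to compound 3 (0.68 log units; beyond the scatter), also lies beyond the scatter and is the cleaner comparison, for methoxy replaces nitro on an aromatic carbon, leaving compound 3 with the highest number of the three, though both steps remain modest.

The step from 3-chlorophenyl to 4-methoxyphenyl changes both the group and its printed ring position, so the compounds shown cannot separate these two changes; 3-methoxyphenyl or 4-chlorophenyl would be needed to do that. From the compounds shown here alone, how an unsubstituted phenyl or a 4-aminophenyl would read at this place also remains open. Nothing shown here accounts for the higher number of compound 3.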